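Aryl-linked aminomethyl in place of the aminopropyl chain

A few compounds are considered here, and "the series" means these few. Any claim that something is new, unique, unknown or untested is made for them only; others in the source may bear on it.

Compound 1 `CCCCCCCCCCc1ccc(-c2noc(CCCN)n2)cc1` gives the highest of the three numbers in an assay on HeLa cells for inhibition of sphingosine-1-phosphate transporter SPNS2 (Mus musculus), read by LC-MS, tested at 2 uM (a lower number here means less inhibition, a higher number more inhibition at the concentration tested (going by the name of the read-out)), with 67%, though compound 2 is not separated from it beyond the scatter. Compound 2 `CCCCCCCCCCc1ccc(-c2noc(CC3CNC3)n2)cc1` gives 63%, and a number 4 percentage points lower from compound 1 to compound 2 (within the scatter). Compound 3 `CCCCCCCCCCc1ccc(-c2noc([C@@H]3CCCN3)n2)cc1` gives 21%, and a number 46 percentage points lower from compound 1 to compound 3 (beyond the scatter).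

Compound 4 `CCCCCCCCCCc1ccc(-c2noc(-c3cccc(CN)c3)n2)cc1` differs from compound 1 by 3-(aminomethyl)phenyl in place of 3-aminopropyl on an aromatic carbon. Both earlier steps bear on it: placing a ring in the amine-bearing group while keeping a free amine cost little from compound 1 to compound 2, whereas folding the amine into the ring cost much from compound 1 to compound 3. Compound 4 keeps the free primary amine, so a number 12 percentage points lower from compound 1 to compound 4 (beyond the scatter) is expected to be modest. Compound 4 is therefore expected to give 55%, between 30% and 78%.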

Compound 4, a percentage reported as inhibition, at one concentration (the size of the read-out at that concentration, not a potency): 2%
Estimate against measurement, compound 4: 53 percentage points above, and the stated range ends above it.
By their numbers in this assay, from the lowest: compound 4; then compound 3; then compounds 2 and 1 (each within the scatter of the next).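

A free primary amine alone does not hold inhibition on this aromatic carbon: 3-(aminomethyl)phenyl in place of 3-aminopropyl gives a number 65 percentage points lower from compound 1 to compound 4 (beyond the scatter). The same group in place of (azetidin-3-yl)methyl gives a number 61 percentage points lower from compound 2 to compound 4 (beyond the scatter), and in place of pyrrolidin-2-yl it gives a number 19 percentage points lower from compound 3 to compound 4 (beyond the scatter), so the earlier reading that a retained free amine costs little does not extend to compound 4. Nothing available explains this loss.

Still open, going by these compounds, is whether a 4-aminobutyl chain or a piperidin-4-yl group on the same aromatic carbon would keep the inhibition seen with compound 1.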